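Meta substituent swap on the aryl ring: hydroxy to cyano

This account rests on a few compounds, and the source may have more. Where it says the series, first, only, none or still open, it means among the compounds named here.

The series shares one core, seen in compound 1 `COC(=O)C1=C(C)N=C(C)/C(=C(\O)OC)C1c1cc(Cl)cc(Cl)c1`, compound 2 `COC(=O)C1=C(C)N=C(C)/C(=C(\O)OC)C1c1cccc(O)c1` and compound 3 `COC(=O)C1=C(C)N=C(C)/C(=C(\O)OC)C1c1cccc(N(C)C)c1`, and varies the aryl group on the saturated ring carbon. In a functional assay (muscle tissue) with Cavia porcellus as the target (on this read-out lower numbers stand for an effect already at smaller amounts and higher numbers for an effect only at larger amounts of compound), compound 1 gives 93.3 nM, compound 2 gives 1000 nM and compound 3 gives 891 nM. Compound 2 thus has the highest number of the three; compound 3 sits within the scatter of it, compound 1 well below it.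

Two steps are known. The change of aryl group gave an 11-fold higher number from compound 1 to compound 2 (1.03 log units; beyond the scatter). Replacing the substituent on the aromatic carbon gave a 1.1-fold lower number from compound 2 to compound 3 (0.05 log units; within the scatter), so the exchange of one group at that carbon did not move the number beyond the scatter.

Compound 4 `COC(=O)C1=C(C)N=C(C)/C(=C(\O)OC)C1c1cccc(C#N)c1` differs from compound 2 by cyano in place of hydroxy on an aromatic carbon. The step from compound 2 to compound 3 is the only one at the same place and was within the scatter; the large step from compound 1 to compound 2 involved a different change and is not directly comparable. A small step in this assay is therefore expected, if anything toward a lower number. The expected step is a 1.7-fold lower number from compound 2 to compound 4 (0.22 log units; within the scatter). For compound 4 the estimated value is 600 nM, between 200 nM and 2000 nM.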

Compound 4, half-maximal effective concentration: 34.7 nM
Compound 4: middle estimate off by 17-fold (1.24 log units), on the high side; measured number outside the range, below it.
By their numbers in this assay, from the lowest: compound 4; then compound 1; then compounds 3 and 2 (each within the scatter of the next).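

At this aromatic carbon the choice of group clearly counts in this assay: cyano in place of hydroxy gives a 29-fold lower number from compound 2 to compound 4 (1.46 log units; beyond the scatter), and cyano in place of dimethylamino gives a 26-fold lower number from compound 3 to compound 4 (1.41 log units; beyond the scatter), whereas the exchange of hydroxy for dimethylamino had stayed within the scatter. The 3-cyanophenyl group in place of 3,5-dichlorophenyl gives a 2.7-fold lower number from compound 1 to compound 4 (0.43 log units; beyond the scatter), so the dichloro pattern is not required for the lowest number among these compounds. No measurement at hand bears on why cyano separates from the other groups.

On these data alone, whether the low number is particular to cyano or extends to other groups at this carbon, such as a carboxylic acid, an amide or a methyl ester, stays open. Also open, as far as these compounds go, is whether adding a chlorine to the 3-cyanophenyl ring would lower or raise the number.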